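Adding an ethyl group to an inactive acid

The compounds below may be only part of what the source reports. "The series", "measured", "known", "first", "only" and "open" are said of these compounds alone.

Measured compounds:
- compound 1, `CCOC(=O)CSc1nc(Cl)cc(Nc2ccc3ncccc3c2)n1`, 86.3%
- compound 2, `O=C(O)C(Sc1nc(Cl)cc(Nc2ccc3ncccc3c2)n1)c1ccccc1`, "not active" (no number reported)

In an assay for inhibition of Polyunsaturated fatty acid 5-lipoxygenase (Homo sapiens), tested at 1 uM (a higher number here means a weaker effect of the compound at the concentration tested, a lower number a stronger effect), compound 1 gives 86.3%, a weak effect. In this assay compound 2 is reported as "not active" (no number reported), so no single number stands for it; on the numbers shown it sits at the weak end together with compound 1, with nothing to rank the two. Compound 3, `CCOC(=O)C(Sc1nc(Cl)cc(Nc2ccc3ncccc3c2)n1)c1ccccc1`, is the unmeasured partner of compound 2. The difference between them is ethyl in place of hydrogen on an oxygen next to a carbonyl group; cut one bond further out, it reads carboxy to ethoxycarbonyl. For the measured compounds named here, no step between measured compounds describes this change, and compound 1, which already carries an ethoxycarbonyl group, gives a weak effect. The expectation for compound 3 is therefore a weak effect, with a reading near that of compound 1 or again no number at all. Compound 3 is estimated at 85%, within 65% to 100%.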

Compound 3, a percentage reported as activity, at one concentration (the size of the read-out at that concentration, not a potency): 52.7%
For compound 3 the middle estimate is 32.3 percentage points above the measured one; the measured number lies below the stated range.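

Compound 2 is reported as "not active" in this assay, while compound 3, with ethyl in place of hydrogen on the oxygen next to a carbonyl group, gives 52.7% as a real number, though the missing number for compound 2 means this change has no measurable size. Among the ethyl compounds, phenyl in place of hydrogen on the saturated chain carbon bound to a carbonyl carbon and a sulfur also matters, giving a number 33.6 percentage points lower from compound 1 to compound 3 (beyond the scatter) in this read-out, so a stronger effect comes with phenyl here. No measurement shown explains why either change acts as it does.

As far as these compounds go, whether methyl, propyl or another chain in place of ethyl would read the same remains open. So does the effect of benzyl or cyclohexyl in place of phenyl on that chain carbon.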